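This account rests on a few compounds, and the source may have more. Where it says the series, first, only, none or still open, it means among the compounds named here.

Measured compounds:
compound 1 `Cc1cc(C)cc(S(=O)(=O)c2c(C(=O)NC(C)C(=O)NCc3ccco3)[nH]c3ccc(Cl)cc23)c1`: 24200 nM
compound 2 `Cc1cc(C)cc(S(=O)(=O)c2c(C(=O)Nc3ccnc(C#N)c3)[nH]c3ccc(Cl)cc23)c1`: 6840 nM
compound 3 `Cc1cc(C)cc(S(=O)(=O)c2c(C(=O)NCC(=O)NCc3ccco3)[nH]c3ccc(Cl)cc23)c1`: > 50000 nM

In an ADME assay on MT4 cells (Homo sapiens) for cytotoxicity, read by MTT assay (on this read-out lower numbers stand for higher toxicity in this test and higher numbers for lower toxicity in this test), compound 3 gives only a limit, > 50000 nM, not a number; of the three values shown it sits highest, at the limit of > 50000 nM in this assay, at which 1 of the 3 values shown sits. Compound 4 `Cc1cc(C)cc(S(=O)(=O)c2c(C(=O)NCc3n[nH]c4ccccc34)[nH]c3ccc(Cl)cc23)c1` differs from compound 3 by 1H-indazol-3-yl in place of ((furan-2-yl)methyl)carbamoyl on a saturated chain carbon bound to an amide-type nitrogen. Going by the values given here, two measured steps touch the same part of the molecule: an at least 7.3-fold higher number from compound 2 to compound 3 (0.86 log units; beyond the scatter) and an at least 2.0-fold higher number from compound 1 to compound 3 (0.31 log units; beyond the scatter). Both led up to compound 3. Putting an aromatic ring system back where the (((furan-2-yl)methyl)carbamoyl)methyl stood resembles a partial reversal of an at least 7.3-fold higher number from compound 2 to compound 3 (0.86 log units; beyond the scatter), so a modest lower number is expected for compound 4, as an at least 2.5-fold lower number from compound 3 to compound 4 (0.39 log units; beyond the scatter). Compound 4 is therefore estimated at 20000 nM, with a likely range from 7000 nM to 50000 nM.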

Compound 4, half-maximal cytotoxic concentration: > 50700 nM
Compound 4 ended at the assay's limit; the forecaster's own chance of this, stated with the estimate: 30%; middle value at least 2.5-fold (0.40 log units) from the limit.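

In this assay, compound 4 gives > 50700 nM, which is again a limit of the assay and not a number. An aromatic ring system on the saturated chain carbon bound to an amide-type nitrogen therefore need not bring the number down, as the steps show: an at least 7.4-fold higher number from compound 2 to compound 4 (0.86 log units; beyond the scatter), and an at least 2.0-fold higher number from compound 1 to compound 4 (0.32 log units; beyond the scatter). The step between compound 3 and compound 4 cannot be read, as both values are limits. From the compounds shown here alone, whether these two differ at all stays open, as does how an amine or a carboxylic acid in place of the 1H-indazol-3-yl would read.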